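This account rests on a few compounds, and the source may have more. Where it says the series, first, only, none or still open, it means among the compounds named here.

Of the compounds shown here, three have so far been measured in a physicochemical assay for solubility, in phosphate buffer, measured as kinetic solubility, with a stated time of 18 h, at pH 7.4; a lower number here means a less soluble compound, a higher number a more soluble compound. Compound 1 `O=C(Nc1ccc(Cl)cc1)c1cc([N+](=O)[O-])ccc1Cl` gives 3000 nM. Compound 2 `C/C=C/C(=O)Nc1cccc(-c2nc3ccccc3s2)c1` gives 110 nM, and compound 3 `O=C(O)/C=C/C(=O)Nc1cccc(-c2nc3ccccc3s2)c1` gives 56000 nM, the highest of the three numbers, with compound 1 the nearest to it and compound 2 the furthest from it. Compound 4 `CC(Cl)C(=O)Nc1cccc(-c2nc3ccccc3s2)c1` has not yet been measured. It differs from compound 3 in a single place: 1-chloroethyl in place of 2-carboxyethenyl on a carbonyl carbon. The carboxy group that distinguishes compound 3 from compound 2 is thereby gone, and compound 4, like compound 2, carries no carboxy group. Among the compounds with values here, only one measured step between two compounds that differ in a single place bears on this change, and it runs the other way, namely a 510-fold higher number from compound 2 to compound 3 (2.71 log units; beyond the scatter). Undoing that change is therefore expected to bring a drop of comparable size in this assay, landing compound 4 close to the number of compound 2. The expected step is a 280-fold lower number from compound 3 to compound 4 (2.45 log units; beyond the scatter). Compound 4 is thus estimated to give about 200 nM, with a likely range from 40 nM to 1000 nM.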

Compound 4, solubility: 830 nM
Beside the measured number, compound 4's estimate is 4.2-fold (0.62 log units) below it; the range from low to high includes it.
By their numbers in this assay, from the lowest: compound 2; then compound 4; then compound 1; then compound 3.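

In this assay, the step of a 67-fold lower number from compound 3 to compound 4 (1.83 log units; beyond the scatter) shows that this position on the carbonyl carbon responds strongly when 2-carboxyethenyl gives way to 1-chloroethyl, a group with no carboxy. The two groups without a carboxy also differ from each other: 1-chloroethyl in place of prop-1-en-1-yl gives a 7.5-fold higher number from compound 2 to compound 4 (0.88 log units; beyond the scatter), a modest step but beyond the scatter. So the number here depends on more than the presence or absence of the carboxy, and nothing at hand explains either step.

The compounds shown do not separate the part of the chlorine from that of the saturated chain, which a plain ethyl group on the same carbonyl carbon could do. On these data alone, how a chain ending in an amine or a hydroxyl would read at this position also remains open.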